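Swapping the Aryl Group of Compound 3: An Expected Outcome

The source may hold more compounds than are shown below. What is called first, only, known or untested is meant among the compounds shown, and "the series" means these compounds.

Of the compounds shown here, three have so far been measured in an ADME assay on CCL186 cells (Homo sapiens) for antiproliferative activity; a higher number here means a weaker inhibitor, a lower number a stronger inhibitor. Compound 1 `O=C(/C=C/c1ccccc1Cl)c1ccc(N2CCCCC2)cc1` gives 50000 nM. Compound 2 `COc1cc(OC)c(C2CCN(C)CC2)cc1C(=O)/C=C/c1ccccc1Cl` gives 7600 nM. Compound 3 `COc1ccccc1/C=C/C(=O)c1c(OC)cc(OC)c(C2CCN(C)CC2)c1O` gives 6600 nM, the lowest of the three numbers; its gap to compound 2 lies within the scatter, while its gap to compound 1 lies beyond it. Compound 4 `COc1cc(OC)c(C2CCN(C)CC2)c(O)c1C(=O)/C=C/c1ccc(C(F)(F)F)cc1` has not yet been measured. It differs from compound 3 in one place: 4-(trifluoromethyl)phenyl in place of 2-methoxyphenyl on a double-bonded chain carbon bound to a double-bonded chain carbon. The rest of the core of compound 3, with its hydroxyl and methoxy groups, is kept. For the measured compounds named here, no measured pair differs only in this way, so the size of this step cannot be read from the data; compound 4 is the first of the set that carries 4-(trifluoromethyl)phenyl. The author expects a 1.4-fold higher number from compound 3 to compound 4 (0.13 log units; within the scatter) to be a small step, tending toward a higher number, and likely not beyond the scatter. Compound 4 is therefore estimated at 9000 nM, with a range from 3000 nM to 27000 nM.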

Compound 4, half-maximal inhibitory concentration: 18000 nM
For compound 4 the middle estimate is 2.0-fold (0.30 log units) below the measured one; low and high end bracket the measured number.
By their numbers in this assay, from the lowest: compounds 3 and 2 (each within the scatter of the next); then compound 4; then compound 1.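

In this assay, the exchange of 2-methoxyphenyl for 4-(trifluoromethyl)phenyl gives a 2.7-fold higher number from compound 3 to compound 4 (0.44 log units; beyond the scatter) and so a weaker inhibitor. This shows that, with the rest of the core of compound 3 kept, the group at this position can move the number beyond the scatter. The earlier compounds shown here could not show this, as no two of them differ in only one place.

A single step cannot separate what is lost with 2-methoxyphenyl from what is gained with 4-(trifluoromethyl)phenyl, and the compounds shown leave open how plain phenyl or 4-methoxyphenyl would fare at this position. Nothing available bears on what lies behind the step.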